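This account rests on a few compounds, and the source may have more. Where it says the series, first, only, none or still open, it means among the compounds named here.

In an assay on isolated protein for inhibition of Long-chain-fatty-acid--CoA ligase 1 (Homo sapiens), read by mass spectrometry, with a stated time of 90 min, in the presence of a further agent that is not named here (a higher number here means a weaker inhibitor, a lower number a stronger inhibitor), compound 1 `Cc1cccc(Cc2nc3cc(O[C@H]4CC[C@@H](C(=O)O)CC4)ccc3n2C)c1` gives 42 nM, the lowest of the three numbers recorded here. Compound 3 `Cc1cccc(Cc2nc3cc(O[C@H]4CC[C@@H](C(=O)O)CC4)c(Cl)cc3n2C)c1` gives 47 nM in this assay, and compound 2 `Cn1c(Cc2cccc(C#N)c2)nc2cc(O[C@H]3CC[C@@H](C(=O)O)CC3)ccc21` gives 51000 nM. The step of a 1.1-fold higher number from compound 1 to compound 3 (0.05 log units; within the scatter) shows that a chloro in place of a hydrogen on the core left the number essentially unchanged, whereas the step of a 1200-fold higher number from compound 1 to compound 2 (3.08 log units; beyond the scatter) shows how strongly the number can move when the methyl on the pendant ring is exchanged for a cyano.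

Compound 4 `Cc1cccc(Cc2nc3c(Cl)c(O[C@H]4CC[C@@H](C(=O)O)CC4)ccc3n2C)c1` differs from compound 1 in one place: chloro in place of hydrogen on an aromatic carbon. The step from compound 1 to compound 3 bears most directly on this change, since it is the same exchange of hydrogen for chloro on the same core, only at a different carbon, and it stayed within the scatter. On that basis compound 4 is expected to show no step beyond the scatter, a 1.4-fold higher number from compound 1 to compound 4 (0.15 log units; within the scatter), with the wider range reflecting the new position. The estimate for compound 4 is 60 nM, between 25 nM and 200 nM.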

Compound 4, half-maximal inhibitory concentration: 61000 nM
Compound 4: the middle estimate sits 1000-fold (3.01 log units) below what was measured, and the stated range ends below it.
By their numbers in this assay, from the lowest: compounds 1 and 3 (each within the scatter of the next); then compounds 2 and 4 (each within the scatter of the next).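

Placing a chloro on this aromatic carbon, ortho to a fused ring and ortho to a large group, gives a 1500-fold higher number from compound 1 to compound 4 (3.16 log units; beyond the scatter), so one added atom here can move the number far beyond the scatter. The same exchange on another carbon of the core gives a 1.1-fold higher number from compound 1 to compound 3 (0.05 log units; within the scatter), which shows that the outcome of adding a chloro to this core depends strongly on which carbon carries it. Nothing measured here bears on why this position behaves so differently.

As far as these compounds go, whether a fluoro or a methyl on this same carbon would raise the number as far as the chloro does remains open. From the compounds shown here alone, it is also open how a methoxy on either of these two carbons would compare with the chloro.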